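One Added Chain Carbon on the Dibutylamino Side Chain

The source may report more compounds than this note shows. Statements on the series, on what has been measured and on what is new or still open speak of the compounds shown alone.

Among the compounds with values here, in a functional assay on LNCaP cells (Homo sapiens) for antiproliferative activity, read by WST assay, with a stated time of 3 days (on this read-out lower numbers stand for stronger inhibition and higher numbers for weaker inhibition), compound 2 (`CCCCN(CCCC)CCCOc1c(-c2cc(OC)c(OC)c(OC)c2)oc2ccccc2c1=O`) gives 9000 nM, the lower of the two numbers so far, while compound 1 (`CCN(CC)CCCOc1c(-c2cc(OC)c(OC)c(OC)c2)oc2ccccc2c1=O`) gives 37600 nM. Compound 3 (`CCCCN(CCCC)CCCCOc1c(-c2cc(OC)c(OC)c(OC)c2)oc2ccccc2c1=O`) differs from compound 2 by (dibutylamino)methyl in place of dibutylamino on a saturated chain carbon, three bonds along the chain from an oxygen on an aromatic ring, which also reads as 2-(dibutylamino)ethyl to 3-(dibutylamino)propyl. Within the data shown here, the only measured step, a 4.2-fold lower number from compound 1 to compound 2 (0.62 log units; beyond the scatter), changed the groups on the nitrogen rather than the chain, so it bears only indirectly and no measured step shows the effect of chain length. The estimated step is a 1.3-fold lower number from compound 2 to compound 3 (0.11 log units; within the scatter), and none beyond the scatter is expected. For compound 3 the estimate is 7000 nM, with an expected range of 2500 nM to 20000 nM.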

Compound 3, half-maximal inhibitory concentration: 7800 nM
Beside the measured number, compound 3's estimate is 1.1-fold (0.05 log units) below it; measured number inside the range.
By their numbers in this assay, from the lowest: compounds 3 and 2 (each within the scatter of the next); then compound 1.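

In this assay, the step of a 1.2-fold lower number from compound 2 to compound 3 (0.06 log units; within the scatter) shows that, on this saturated chain carbon, (dibutylamino)methyl and dibutylamino cannot be told apart in this read-out. The step of a 4.8-fold lower number from compound 1 to compound 3 (0.68 log units; beyond the scatter) stands beyond the scatter, though it changes the groups on the nitrogen as well as the chain length. Nothing available bears on why these numbers take these values. Still open, as far as these compounds go, is how a morpholine or a piperidine would read in place of the dibutylamino group, and how a longer chain would read.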